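Trimming the amino-acid substituent: compound 3 to compound 4

The compounds below may be only part of what the source reports. "The series", "measured", "known", "first", "only" and "open" are said of these compounds alone.

Compound 3 `CC1=CCC[C@](C)(CC/C(C)=C/CC2=C(O)C(=O)C=C(N[C@@H](C(=O)O)[C@@H](C)O)C2=O)[C@@H]1C` is measured only as a limit in an ADME assay on L1210 cells (Mus musculus) for cytotoxicity, with a stated time of 48 h (a lower number here means a stronger inhibitor, a higher number a weaker inhibitor), where compound 3 gives > 10 ug/mL. Compound 1 `C=C1[C@H](C)CCC[C@]1(C)CC/C(C)=C/CC1=C(O)C(=O)C=C(N[C@@H](CO)C(=O)O)C1=O` likewise reaches only the limit, giving > 10 ug/mL. Compound 2 `COC1=CC(=O)C(O)=C(C/C=C(\C)CC[C@@]2(C)CCC=C(C)[C@H]2C)C1=O` gives 2 ug/mL. Among the measured compounds shown here, the one step within the measured pairs is an at least 5.0-fold higher number from compound 2 to compound 3 (0.69 log units; beyond the scatter), and its size cannot be read in full because of the limit of > 10 ug/mL in this assay, at which 2 of the 3 values shown sit.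

Compound 4 `CC1=CCC[C@](C)(CC/C(C)=C/CC2=C(O)C(=O)C=C(N[C@@H](CO)C(=O)O)C2=O)[C@@H]1C` differs from compound 3 by 1-carboxy-2-hydroxyethyl in place of 1-carboxy-2-hydroxypropyl on an amine nitrogen. For the measured compounds named here, no measured step follows this change; compound 1 carries the same entering group and gives > 10 ug/mL, a limit. Compound 4 is therefore expected to stay at the limit, with a step that the limit leaves unreadable from compound 3 to compound 4 showing no step beyond the scatter. The estimate for compound 4 is 15 ug/mL, spanning 8 ug/mL to 40 ug/mL.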

Compound 4, half-maximal inhibitory concentration: > 10 ug/mL
Compound 4: a limit, no number; the forecaster's own chance of this, stated with the estimate: 80%; the middle value lies beyond the limit too.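

Replacing methoxy on a double-bonded ring carbon with (1-carboxy-2-hydroxyethyl)amino gives the same outcome in this assay as the (1-carboxy-2-hydroxypropyl)amino group did: an at least 5.0-fold higher number from compound 2 to compound 4 (0.69 log units; beyond the scatter). The weaker reading at this position therefore holds for both amino-acid substituents shown, compound 3 and compound 4. The steps from compound 3 and from compound 1 to compound 4 cannot be read because both ends are limits: the limit of > 10 ug/mL in this assay, at which 3 of the 4 values shown sit.

As far as these compounds go, whether removing the one carbon from the side chain changes the number at all stays open. So does whether the loss follows the carboxylic acid or the amine nitrogen, which a plain amino group or a methyl ester at this place could separate.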